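The compounds below may be only part of what the source reports. "The series", "measured", "known", "first", "only" and "open" are said of these compounds alone.

Three compounds share one core and differ only in the aromatic group on the double-bonded chain carbon. Compound 3 `C=C(Br)C(=O)Nc1ccc2c(c1)/C(=C/c1ccsc1)C(=O)N2` gives 190 nM in a functional assay on Jurkat cells (Homo sapiens) for antiproliferative activity, read by MTT assay, with a stated time of 72 h (a lower number here means a stronger inhibitor, a higher number a weaker inhibitor), the lowest of the three numbers, though compound 1 `C=C(Br)C(=O)Nc1ccc2c(c1)/C(=C/c1cccs1)C(=O)N2` with 210 nM and compound 2 `C=C(Br)C(=O)Nc1ccc2c(c1)/C(=C\c1sccc1C)C(=O)N2` with 340 nM both lie within the scatter of it. For the measured compounds named here, the single step among the measured compounds, a 1.1-fold lower number from compound 1 to compound 3 (0.04 log units; within the scatter), shows that exchanging the two thiophenyl groups leaves the number essentially unchanged.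

Compound 4 `C=C(Br)C(=O)Nc1ccc2c(c1)/C(=C/c1sccc1C)C(=O)N2` is not yet measured. It differs from compound 3 in one place: 3-methylthiophen-2-yl in place of thiophen-3-yl on a double-bonded chain carbon bound to a double-bonded ring carbon. The step from compound 1 to compound 3 bears directly on the thiophenyl exchange, and compound 2 already carries the same 3-methylthiophen-2-yl group while giving a number within the scatter of compound 3. On that basis no step beyond the scatter is expected, and the step of a 1.4-fold higher number from compound 3 to compound 4 (0.15 log units; within the scatter) is estimated to be small. Compound 4 is therefore expected to give about 270 nM in this assay, within a range from 140 nM to 520 nM.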

Compound 4, half-maximal inhibitory concentration: 530 nM
The estimate for compound 4 lay 2.0-fold (0.29 log units) below the measured number; measured number outside the range, above it.
By their numbers in this assay, from the lowest: compounds 3, 1, 2 and 4 (each within the scatter of the next, the first and the last beyond it).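

For the compounds shown here, the position is less indifferent to change than the thiophenyl exchange suggested: in this assay, a 2.8-fold higher number from compound 3 to compound 4 (0.45 log units; beyond the scatter) lies beyond the scatter, and so does a 2.5-fold higher number from compound 1 to compound 4 (0.40 log units; beyond the scatter), where the only change is methyl in place of hydrogen on an aromatic carbon. With the drawn configuration held the same, the added methyl thus gives a number that can be told apart from that of the unsubstituted thiophen-2-yl. Configuration at the double bond, by contrast, gives no separable step, since a 1.6-fold higher number from compound 2 to compound 4 (0.19 log units; within the scatter) stays within the scatter, and that pair isolates this one feature: the fact that compounds 2 and 4 differ only in the configuration as drawn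

As far as these compounds go, whether ethyl, methoxy or an amine in place of that methyl would give a number like that of compound 4 remains open. From the compounds shown here alone, it is also open whether a methyl on thiophen-3-yl would give a similar step.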